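The source may hold more compounds than are shown below. What is called first, only, known or untested is meant among the compounds shown, and "the series" means these compounds.

Values so far in a physicochemical assay for lipophilicity, at pH 7.4 (on this read-out lower numbers stand for lower lipophilicity and higher numbers for higher lipophilicity), are as follows.
Compound 1 `COc1cc2[nH]c(C)c(C3CCCCC3)c(=O)c2cc1Cl` at 3.04
Compound 2 `CCCCC#Cc1c(C)[nH]c2cc(OC)c(Cl)cc2c1=O` at 2.45
Compound 3 `CCCCC/C=C/c1c(C)[nH]c2cc(OC)c(Cl)cc2c1=O` at 3.57

Compound 3 stands highest of the three, beyond the scatter of both others. Next in line is compound 4 `COc1cc2[nH]c(C)c(/C=C/C(=O)OC(C)(C)C)c(=O)c2cc1Cl` which has not yet been measured. The change is tert-butoxycarbonyl in place of pentyl on a double-bonded chain carbon bound to a double-bonded chain carbon and reads tert-butoxycarbonyl in place of pentyl on a double-bonded chain carbon bound to a double-bonded chain carbon.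

The closest evidence comes from swapping the group on the aromatic carbon, which gave modest to large steps (a number 0.59 log units lower from compound 1 to compound 2 (beyond the scatter)), (a number 0.53 log units higher from compound 1 to compound 3 (beyond the scatter)) and (a number 1.12 log units higher from compound 2 to compound 3 (beyond the scatter)). Within the data shown here, these show that this assay responds to the chain, but no measured compound carries tert-butoxycarbonyl, and this swap has no direct measure. The hydrogen-bond acceptors enter where pentyl has none. Taking compound 3 at 3.57 as the start and the large step (a number 1.12 log units higher from compound 2 to compound 3 (beyond the scatter)) as the upper guide, a lower number is expected, beyond the scatter but probably not the full size of that step. The expected change is a number 0.72 log units lower from compound 3 to compound 4 (beyond the scatter) (an estimate). For compound 4 the estimated value is 2.85 (expected range 2.35 to 3.35).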

Compound 4, distribution coefficient: 1.81
Compound 4: the middle estimate sits 1.04 log units above what was measured, outside the stated range (below it).
By their numbers in this assay, from the lowest: compound 4; then compound 2; then compound 1; then compound 3.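

The swap of pentyl for tert-butoxycarbonyl on a double-bonded chain carbon bound to a double-bonded chain carbon moves the read-out in this assay further than any earlier step in the series (a number 1.76 log units lower from compound 3 to compound 4 (beyond the scatter)). Among these compounds, the earlier steps changed only the group on the aromatic carbon, so this is the first sign that this assay also responds to a change further out along the chain, with the double bond kept in place. The entering group has 7 heavy atoms against 5 for pentyl and 2 hydrogen-bond acceptors against 0, so within this pair the number falls as the heavy-atom count rises. No measurement here accounts for the size of this fall.

A single swap cannot separate the share of the carbonyl and ester oxygens from that of the tert-butyl part, and a methyl ester, a carboxylic acid or an amide at the same place would divide the step between them. Also open, from the compounds shown here alone, is whether the same group would give a step of similar size on the hex-1-yn-1-yl chain of compound 2.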